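The compounds below may be only part of what the source reports. "The series", "measured", "known", "first", "only" and "open" are said of these compounds alone.

Compound 1, whose structure is `C=C[C@@]1(O)[C@@H](CO)O[C@@H](n2ccc(N)nc2=O)[C@@H]1O`, was tested in a functional assay on KB cells (Homo sapiens), read by MTT assay (on this read-out lower numbers stand for stronger inhibition and higher numbers for weaker inhibition), where compound 1 gives 74300 nM. Compound 2, with the structure `CC#C[C@@]1(O)[C@@H](CO)O[C@@H](n2ccc(N)nc2=O)[C@@H]1O`, differs from it by one change, (prop-1-yn-1-yl in place of vinyl on a saturated ring carbon), and in this assay compound 2 gives 14600 nM, so the change produced a 5.1-fold lower number from compound 1 to compound 2 (0.71 log units; beyond the scatter). Compound 3, whose structure is `C=C[C@@]1(O)[C@@H](CO)O[C@@H](n2ccc(=O)[nH]c2=O)[C@@H]1O`, has a different core; how its core differs from that of compound 1 is not broken down here. In this assay compound 3 gives 51800 nM. Compound 4, with the structure `CC#C[C@@]1(O)[C@@H](CO)O[C@@H](n2ccc(=O)[nH]c2=O)[C@@H]1O`, has not yet been measured. It differs from compound 3 by prop-1-yn-1-yl in place of vinyl on a saturated ring carbon, the same change as that from compound 1 to compound 2. Because that earlier change gave a 5.1-fold lower number from compound 1 to compound 2 (0.71 log units; beyond the scatter), a step of similar size is expected here, estimated as a 4.3-fold lower number from compound 3 to compound 4 (0.64 log units; beyond the scatter). Compound 4 is therefore estimated to give about 12000 nM, most likely between 4000 nM and 35000 nM.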

Compound 4, half-maximal inhibitory concentration: 70800 nM
The estimate for compound 4 lay 5.9-fold (0.77 log units) below the measured number; the measured number lies above the stated range.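

In this assay, putting prop-1-yn-1-yl in place of vinyl did not repeat its earlier effect on the second core, giving a 1.4-fold higher number from compound 3 to compound 4 (0.14 log units; within the scatter). The two steps differ by more than the usual scatter: the same change on two cores in this assay, a 5.1-fold lower number (0.71 log units; beyond the scatter) from compound 1 to compound 2 and a 1.4-fold higher number (0.14 log units; within the scatter) from compound 3 to compound 4, 7.0-fold (0.84 log units) apart, beyond the scatter of two such steps. Among these compounds, this shows that the stronger inhibition seen on the core of compound 1 cannot be assumed on the core of compound 3, but with only two cores it does not show why they differ or how the change would behave on a further core.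

The compounds shown leave open how either core would respond to a longer chain or an amine on that saturated ring carbon. They also leave open whether such groups would separate the two cores in the same way.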